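The source may hold more compounds than are shown below. What is called first, only, known or untested is meant among the compounds shown, and "the series" means these compounds.

Working notes on the series, read in a functional assay on HeLa cells (Homo sapiens) for cytotoxicity, read by MTT assay, with a stated time of 48 h; on this read-out higher numbers stand for weaker inhibition and lower numbers for stronger inhibition. Compound 2 `COc1cc([C@H]2C[C@]2(CO)C(=O)Nc2ccccc2)cc(OC)c1OC` gives > 100000 nM, and this is a limit of the assay, not a number. For the measured compounds named here, compound 1 `COc1cc([C@@H]2C[C@]2(CO)C(=O)NCc2ccc(C)cc2)cc(OC)c1OC` gives 17400 nM, the only actual number so far in this assay.

Compound 3 `COc1cc([C@@H]2C[C@]2(CO)C(=O)Nc2ccccc2)cc(OC)c1OC` is the next point: the two compounds have the same atoms and bonds and differ only in configuration as drawn: 1 of 2 stereo elements differ; a stereocentre at a saturated ring carbon is drawn R in compound 2 and S in compound 3. A stereocentre at a saturated ring carbon is drawn R in compound 2 and S in compound 3. Going by the values given here, no measured pair shows what such a change does, and compound 3 may also report only a limit. A modest move toward stronger inhibition is expected in this assay, with compound 1 at 17400 nM as a guide to the stronger end. The estimated step is an at least 1.6-fold lower number from compound 2 to compound 3 (0.22 log units; that floor lies within the scatter). For compound 3 the estimated value is 60000 nM, with an expected range from 18000 nM to 120000 nM.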

Compound 3, half-maximal inhibitory concentration: 32000 nM
The estimate for compound 3 lay 1.9-fold (0.27 log units) above the measured number; low and high end bracket the measured number.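

In this assay, the configuration at this saturated ring carbon makes a readable difference, and it is the only thing that separates the pair: the fact that compounds 2 and 3 differ only in the configuration as drawn. The step is an at least 3.1-fold lower number from compound 2 to compound 3 (0.49 log units; beyond the scatter), and it is a floor rather than a size, since compound 2 stands at a limit of the assay: the limit of > 100000 nM in this assay, at which 1 of the 3 values shown sits. For the compounds shown here, with compound 3 as a number, the amide substituent can also be read for the first time, and phenyl in place of 4-methylbenzyl on an amide-type nitrogen gives a 1.8-fold higher number from compound 1 to compound 3 (0.26 log units; within the scatter), so this swap shows no change that can be told from the scatter.

The compounds shown leave open what the second stereocentre contributes, and whether the ring-carbon configuration counts the same way with 4-methylbenzyl on the nitrogen. Also open, from the compounds shown here alone, is what an amine or a longer chain in place of phenyl on that nitrogen would give.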